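Methoxy to hydroxy on the 4-chloro-3-methoxyphenyl group

The source may report more compounds than this note shows. Statements on the series, on what has been measured and on what is new or still open speak of the compounds shown alone.

The series shares one core, seen in compound 2 `COc1cc(-c2nn(-c3cccc(NC(=O)Nc4cc(C(F)(F)F)cc(C(F)(F)F)c4)c3)cc2-c2ccncc2)ccc1Cl`. In a functional assay on MDA-MB-231 cells (Homo sapiens) for inhibition, read by sulforhodamine B assay, with a stated time of 48 h (a higher number here means that more compound is tolerated, a lower number that less compound is tolerated), compound 2 gives 3000 nM, the lowest of the two numbers available. Compound 3 `COc1cc(-c2nn(-c3cccc(NC(=O)Nc4cccc(C(F)(F)F)c4)c3)cc2-c2ccncc2)ccc1Cl` carries hydrogen where compound 2 carries trifluoromethyl; in this assay compound 3 gives 25500 nM, so that an 8.5-fold higher number from compound 2 to compound 3 (0.93 log units; beyond the scatter). Compound 1 `O=C(Nc1cccc(-n2cc(-c3ccncc3)c(-c3ccc(Cl)c(O)c3)n2)c1)Nc1cccc(C(F)(F)F)c1` gives > 32500 nM in this assay, which is a limit of the assay and not a number (the limit of > 32500 nM in this assay, at which 1 of the 3 values shown sits).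

The step to compound 4 `O=C(Nc1cccc(-n2cc(-c3ccncc3)c(-c3ccc(Cl)c(O)c3)n2)c1)Nc1cc(C(F)(F)F)cc(C(F)(F)F)c1` alters the 4-chloro-3-methoxyphenyl group: hydrogen in place of methyl on an oxygen on an aromatic ring. Going by the values given here, only one measured step bears on it, and it runs the other way, from hydroxy to methoxy in the trifluoromethyl pair: an at least 1.2-fold lower number from compound 1 to compound 3 (0.10 log units; that floor lies within the scatter). Since compound 1 sits at the limit (the limit of > 32500 nM in this assay, at which 1 of the 3 values shown sits), that step has a floor only, and read in reverse it points to a higher number for compound 4 than for compound 2 in this assay, of a size the data do not fix.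

For compound 4 the expected value in this assay is 8000 nM, within 2500 nM to 32500 nM. This expectation means a 2.7-fold higher number from compound 2 to compound 4 (0.43 log units; beyond the scatter), a step expected to exceed the scatter but left open in size; a result at the limit of the assay is itself possible.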

Compound 4, concentration lethal to 50% of the cells: 3720 nM
The estimate for compound 4 lay 2.2-fold (0.33 log units) above the measured number, within the range that was stated.
By their numbers in this assay, from the lowest: compounds 2 and 4 (each within the scatter of the next); then compound 3. At a limit, above all of these: compound 1.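

On the core of compound 2, hydroxy in place of methoxy on the 4-chloro-3-methoxyphenyl group gives no separation in this assay: a 1.2-fold higher number from compound 2 to compound 4 (0.09 log units; within the scatter). With hydroxy held fixed, the added trifluoromethyl now gives a step of its own, an at least 8.7-fold lower number from compound 1 to compound 4 (0.94 log units; beyond the scatter), so the hydroxy pair also shows a gap beyond the scatter, in the same direction as the gap in the methoxy pair. Compound 1 stands at > 32500 nM, which is a limit of the assay, so the hydroxy pair gives only a floor and its comparison with the methoxy pair stays unsettled: the same change on two cores in this assay, an 8.5-fold higher number (0.93 log units; beyond the scatter) from compound 2 to compound 3 and an at least 8.7-fold higher number (0.94 log units; beyond the scatter) from compound 4 to compound 1; the limit leaves it open whether they differ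

With only methoxy and hydroxy shown at this position, it remains open whether a longer ether such as ethoxy, an amine or a carboxylic acid on the same ring carbon would also leave the number in this assay within the scatter of compound 2. On these data alone, it also remains open whether the match between methoxy and hydroxy holds on the core of compound 3, where the limit on compound 1 prevents a reading of that pair's size.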